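A remote aryl ether swap and the basic amine

The source may hold more compounds than are shown below. What is called first, only, known or untested is meant among the compounds shown, and "the series" means these compounds.

Of the compounds shown here, three sharing one core have been measured in a physicochemical assay for acid dissociation. Compound 1 `CC(C)Cc1ccc2c(NCCCNCc3ccco3)ccnc2c1` gives 9.47. Compound 2 `c1ccc(CCc2ccc3c(NCCCNCc4ccco4)ccnc3c2)cc1` gives 9.47, and no change at the digits printed from compound 1 to compound 2 (within the scatter). Compound 3 `COc1cccc(Oc2ccc3c(NCCCNCc4ccco4)ccnc3c2)c1` gives 9.28; its gap to the others is told by a number 0.19 log units lower from compound 1 to compound 3 (within the scatter) and by a number 0.19 log units lower from compound 2 to compound 3 (within the scatter), so the three numbers sit together within the scatter.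

Compound 4 `CN(C)c1cccc(Oc2ccc3c(NCCCNCc4ccco4)ccnc3c2)c1` differs from compound 3 by dimethylamino in place of methoxy on an aromatic carbon. All three measured steps changed a group on the same aromatic carbon of the core, far from the chain that carries the dissociating proton, and none of them moved this assay beyond the scatter. The change to compound 4 sits one ring further out on that same substituent, so no step beyond the scatter is expected in this assay, in either direction.

The expected step is a number 0.07 log units higher from compound 3 to compound 4 (within the scatter). For compound 4 the estimate in this assay is 9.35, with a range from 9.05 to 9.65.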

Compound 4, acid dissociation constant: 9.28
Beside the measured number, compound 4's estimate is 0.07 log units above it, and the stated range covers the measured number.
By their numbers in this assay, from the lowest: compounds 3, 4, 1 and 2 (each within the scatter of the next).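

In this assay, dimethylamino in place of methoxy on an aromatic carbon, meta to a large group, gives no change at the digits printed from compound 3 to compound 4 (within the scatter), the first step shown at this outer site of the substituent. The wider comparisons agree, with a number 0.19 log units lower from compound 2 to compound 4 (within the scatter) and a number 0.19 log units lower from compound 1 to compound 4 (within the scatter), so 3-(dimethylamino)phenoxy on the shared core stays within the scatter of both the isobutyl and the phenethyl compounds. No supporting information is available to account for this result.

Methoxy and dimethylamino are the only groups shown at this site, so it remains open whether a carboxylic acid there would also stay within the scatter. All four compounds carry the same chain, leaving open what an amide within that chain would do to this read-out.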